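This account rests on a few compounds, and the source may have more. Where it says the series, first, only, none or still open, it means among the compounds named here.

Measured: compound 1 `COc1ccc(Cn2c(=O)n(C3OC(CO)[C@@H](O)[C@H]3O)c3nc(N)nc(O)c32)cc1`, 135 uM; compound 2 `N#Cc1cccc(Cn2c(=O)n(C3OC(CO)[C@@H](O)[C@H]3O)c3nc(N)nc(O)c32)c1`, 3 uM.

Among the compounds with values here, in a functional assay (B cells) with Mus musculus as the target (on this read-out higher numbers stand for an effect only at larger amounts of compound and lower numbers for an effect already at smaller amounts), compound 2 stands lowest of the two numbers measured, and the only step in the set, a 45-fold lower number from compound 1 to compound 2 (1.65 log units; beyond the scatter), is large. Compound 3 `NC(=O)Cn1c(=O)n(C2OC(CO)[C@@H](O)[C@H]2O)c2nc(N)nc(O)c21` differs from compound 2 by carbamoyl in place of 3-cyanophenyl on a saturated chain carbon bound to an aromatic nitrogen. Within the data shown here, no measured step covers this change, but the single known step shows that the group on this saturated chain carbon moves the number strongly, so a large shift is expected here too, most likely back toward a higher number. Compound 3 is therefore estimated at 100 uM, within 15 uM to 600 uM, which would mean a 33-fold higher number from compound 2 to compound 3 (1.52 log units; beyond the scatter).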

Compound 3, concentration for half-maximal effect: 190 uM
The estimate for compound 3 lay 1.9-fold (0.28 log units) below the measured number; low and high end bracket the measured number.
By their numbers in this assay, from the lowest: compound 2; then compounds 1 and 3 (each within the scatter of the next).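

Carbamoyl in place of 3-cyanophenyl gives a 63-fold higher number from compound 2 to compound 3 (1.80 log units; beyond the scatter) in this assay, whereas carbamoyl in place of 4-methoxyphenyl gives only a 1.4-fold higher number from compound 1 to compound 3 (0.15 log units; within the scatter). At this position, therefore, a group without a ring reads level with 4-methoxyphenyl, and among these three groups only 3-cyanophenyl brings the low number. No independent evidence accounts for this difference.

The compounds shown leave open whether the low number needs the nitrile, its placement in 3-cyanophenyl, or both, which plain phenyl or 4-cyanophenyl could separate. On these data alone, how an amine or a carboxylic acid here would read also remains unknown.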